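The source may hold more compounds than are shown below. What is called first, only, known or untested is meant among the compounds shown, and "the series" means these compounds.

Of the compounds shown here, two of a shared core have been measured in an assay on A7R5 cells for displacement of a labelled ligand from Endothelin-1 receptor (Rattus norvegicus); on this read-out lower numbers stand for stronger inhibition and higher numbers for weaker inhibition. Compound 1 `COc1cccc(Sc2c(NS(=O)(=O)c3ccc(C(C)(C)C)cc3)noc2CCCC#N)c1` gives 1300 nM in this assay. Compound 2 `COc1cccc(Sc2c(NS(=O)(=O)c3ccc(C(C)(C)C)cc3)noc2CO)c1` carries a hydroxymethyl group where compound 1 carries a 3-cyanopropyl chain. In this assay compound 2 gives 6200 nM. Compound 2 therefore stands at the higher of the two numbers seen so far, with the step of a 4.8-fold higher number from compound 1 to compound 2 (0.68 log units; beyond the scatter) separating it from compound 1.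

Compound 3 `COc1cccc(Sc2c(NS(=O)(=O)c3ccc(C(C)(C)C)cc3)noc2CCCC(=O)O)c1` differs from compound 2 in one place: 2-carboxyethyl in place of hydroxy on a saturated chain carbon bound to an aromatic carbon. For the measured compounds named here, the single measured step that bears on this change is the one from compound 1 to compound 2, which exchanges a longer chain ending in a nitrile for the hydroxy group and is modest in size. The new change reverses that shortening and returns a chain of the same length, now ending in a carboxylic acid. On that basis a step of roughly the same size in the opposite direction is expected in this assay, so that compound 3 is estimated to sit near compound 1 rather than compound 2. The expected change from compound 2 to compound 3 is a 6.2-fold lower number from compound 2 to compound 3 (0.79 log units; beyond the scatter). Compound 3 is therefore estimated at 1000 nM in this assay, within a range of 250 nM to 4000 nM.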

Compound 3, half-maximal inhibitory concentration: 4300 nM
For compound 3 the middle estimate is 4.3-fold (0.63 log units) below the measured one; measured number above the stated range.
By their numbers in this assay, from the lowest: compound 1; then compounds 3 and 2 (each within the scatter of the next).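

Carboxy in place of cyano on a saturated chain carbon, three bonds along the chain from an aromatic carbon, gives a 3.3-fold higher number from compound 1 to compound 3 (0.52 log units; beyond the scatter) in this assay and shows that at this position the length of the chain does not by itself set the number, since the end of the chain also counts. The exchange of hydroxymethyl for 3-carboxypropyl gives a 1.4-fold lower number from compound 2 to compound 3 (0.16 log units; within the scatter) and so leaves these two very different groups indistinguishable in this read-out, which means that among the three compounds only compound 1, with its nitrile-ended chain, stands apart from the other two. Nothing given here accounts for this difference between the nitrile and the carboxylic acid at the chain end.

The compounds shown leave open whether another group at the end of the same chain, such as an amine or a primary amide, would fall with compound 1 or with compounds 2 and 3. They also leave open how the number depends on chain length with the nitrile kept in place, as a shorter or a longer chain ending in that group would show.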